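Microsomal clearance in the fused urea series: compound 4

The compounds below may be only part of what the source reports. "The series", "measured", "known", "first", "only" and "open" are said of these compounds alone.

Compound 1, `CC(C)c1c(NC(=O)Nc2ccnc(C(F)(F)F)c2)cnc2cc(Cl)nn12`, in an ADME assay on microsomes from liver (Rattus norvegicus) for metabolic stability (a higher number here means faster removal of the compound, a lower number slower removal), returns only the assay limit < 25 mL.min-1.g-1.
Compound 2, `O=C(Nc1cnc(-n2nccn2)c(Cl)c1)Nc1cnc2cc(Cl)nn2c1C1CC1`, in this assay gives 50.4 mL.min-1.g-1.
Compound 3, `CO[C@@H](C)c1c(NC(=O)Nc2cnc(-n3nccn3)c(Cl)c2)cnc2cc(Cl)nn12`, in this assay returns only the assay limit < 25 mL.min-1.g-1.

Going by the values given here, compound 2 is the only member of the three with a numerical read-out in this assay; the other two sit at the limit, as noted in the limit of < 25 mL.min-1.g-1 in this assay, at which 2 of the 3 values shown sit. Compound 4, `COCc1c(NC(=O)Nc2cnc(-n3nccn3)c(Cl)c2)cnc2cc(Cl)nn12`, is not yet measured. It differs from compound 2 in one place: methoxymethyl in place of cyclopropyl on an aromatic carbon.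

Among the compounds with values here, the only measured step that bears on this change is the one to compound 3, where an at least 2.0-fold lower number from compound 2 to compound 3 (0.30 log units; that floor lies within the scatter). That step replaces the same cyclopropyl on the same aromatic carbon with a related methoxy-bearing group, and it drops the read-out to the limit; its floor lies within the usual scatter, so the true size is not fixed. For compound 4 a step in the same downward direction is expected, of similar or smaller size, with a fair chance that the assay again reports only the limit.

Compound 4 is expected to give about 26 mL.min-1.g-1 in this assay, within 12 mL.min-1.g-1 to 52 mL.min-1.g-1. That expectation amounts to a 1.9-fold lower number from compound 2 to compound 4 (0.29 log units; within the scatter).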

Compound 4, intrinsic clearance in microsomes: < 25 mL.min-1.g-1
Compound 4: no number, only a limit; the forecaster's own chance of this, stated with the estimate: 50%; middle value at least 1.0-fold (0.01 log units) from the limit.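

In this assay compound 4 returns < 25 mL.min-1.g-1, which is a limit of the assay and not a number. Methoxymethyl in place of cyclopropyl on this aromatic carbon, next to the ring nitrogen, gives an at least 2.0-fold lower number from compound 2 to compound 4 (0.30 log units; that floor lies within the scatter), so a second oxygen-bearing chain at this position joins compound 3 at the limit, and the methyl on the chain carbon of compound 3 is not needed to get there. The step between compound 3 and compound 4 cannot be read, since both are limits, and the measured set now sits mostly at that floor: the limit of < 25 mL.min-1.g-1 in this assay, at which 3 of the 4 values shown sit.

From the compounds shown here alone, how far compound 3 and compound 4 lie under the limit stays open, so the true size of either change from cyclopropyl is not fixed, and compound 2 remains the only numerical read-out. Also open, going by these compounds, is whether the chain oxygen or the loss of the three-membered ring goes with the lower read-out; an ethyl or propyl chain on the same carbon, with the rest of compound 4 unchanged, would bear on that, ideally in a range where the assay returns a number.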